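Amide nitrogen change from compound 2 to compound 3

The source may hold more compounds than are shown below. What is called first, only, known or untested is meant among the compounds shown, and "the series" means these compounds.

Within the data shown here, in a functional assay on Huh-7 cells (Homo sapiens) for inhibition, read by MTT assay, with a stated time of 48 h (on this read-out lower numbers stand for stronger inhibition and higher numbers for weaker inhibition), compound 2 (`COc1ccc(CNC(=O)/C=C/c2coc3cc(OC)ccc3c2=O)cc1`) gives 7570 nM as the lower of the two numbers so far, against compound 1 (`COc1ccc2c(=O)c(/C=C/C(=O)Nc3ccccc3Cl)coc2c1`) at 58400 nM on the same read-out. Compound 3 (`COc1ccc2c(=O)c(/C=C/C(=O)Nc3ccc(F)cc3)coc2c1`) carries 4-fluorophenyl in place of 4-methoxybenzyl on an amide-type nitrogen. Among the measured compounds shown here, one measured step bears on this change (a 7.7-fold lower number from compound 1 to compound 2 (0.89 log units; beyond the scatter)), modest in size and beyond the scatter, with 4-methoxybenzyl in place of 2-chlorophenyl on that nitrogen. Compound 3 returns to a substituted phenyl group, but a different one, and the effect of 4-fluorophenyl itself remains unmeasured. For the measured compounds named here, with compound 1 at 58400 nM as the only phenyl example, a move to a higher number is expected in this assay, smaller than the measured step. The expected change is a 3.3-fold higher number from compound 2 to compound 3 (0.52 log units; beyond the scatter) (an estimate). For compound 3 the estimated value is 25000 nM (expected range 9000 nM to 60000 nM).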

Compound 3, half-maximal inhibitory concentration: 33900 nM
Beside the measured number, compound 3's estimate is 1.4-fold (0.13 log units) below it; low and high end bracket the measured number.
By their numbers in this assay, from the lowest: compound 2; then compounds 3 and 1 (each within the scatter of the next).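

In this assay, the change on the amide-type nitrogen gives a 4.5-fold higher number from compound 2 to compound 3 (0.65 log units; beyond the scatter), so a second phenyl group, carrying a different halogen at a different place, also falls on the weaker side of the 4-methoxybenzyl of compound 2. Between the two phenyl amides, the change gives a 1.7-fold lower number from compound 1 to compound 3 (0.24 log units; within the scatter), so 4-fluorophenyl and 2-chlorophenyl are not separated on this read-out, and within these two compounds the choice of halogenated phenyl group has no readable effect. No supporting data are available to explain either step.

Compound 2 differs from both phenyl amides in the carbon link to the nitrogen and in the methoxy group, so these two features remain unseparated. An unsubstituted benzyl or a 4-methoxyphenyl group on that nitrogen would tell them apart.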